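Phenyl sulfone in place of the benzyl sulfonamide

The compounds below may be only part of what the source reports. "The series", "measured", "known", "first", "only" and "open" are said of these compounds alone.

The three measured compounds share a urea-linked core, shown for compound 1 as `CNS(=O)(=O)c1ccc(NC(=O)NCc2ccncc2)cc1` and, with a different linker, for compound 2 as `CCOC(=O)c1ccc(N/C(=N\C#N)NCc2ccncc2)cc1`. In an assay on isolated protein for activation of Nicotinamide phosphoribosyltransferase (Homo sapiens) (on this read-out lower numbers stand for an effect already at smaller amounts and higher numbers for an effect only at larger amounts of compound), compound 1 gives 3230 nM and compound 2 gives 41400 nM. Compound 3, `CN(Cc1ccccc1)S(=O)(=O)c1ccc(NC(=O)NCc2ccncc2)cc1`, gives 23 nM in this assay, the lowest of the three numbers; its nearest neighbour is compound 1, and compound 2 lies furthest. Among the measured compounds shown here, the one step that bears on the next change is a 140-fold lower number from compound 1 to compound 3 (2.15 log units; beyond the scatter), which shows how much the group on the sulfonyl end matters.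

Compound 4, `O=C(NCc1ccncc1)Nc1ccc(S(=O)(=O)c2ccccc2)cc1`, differs from compound 3 in one place: phenyl in place of benzyl(methyl)amino on a sulfonyl sulfur. An aromatic ring remains at that end, so the gain seen in compound 3 is expected to be kept in part, but the group that carried it is not the same. A moderate rise is therefore expected, an 8.7-fold higher number from compound 3 to compound 4 (0.94 log units; beyond the scatter). Compound 4 is estimated at 200 nM in this assay, within 40 nM to 1000 nM.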

Compound 4, half-maximal effective concentration: 85 nM
Compound 4: the middle estimate sits 2.4-fold (0.37 log units) above what was measured, and the stated range covers the measured number.
By their numbers in this assay, from the lowest: compound 3; then compound 4; then compound 1; then compound 2.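

In this assay the sulfonyl end does not need a sulfonamide nitrogen to give a low number. There is a 3.7-fold higher number from compound 3 to compound 4 (0.57 log units; beyond the scatter) and, set against the small methylamino group, a 38-fold lower number from compound 1 to compound 4 (1.58 log units; beyond the scatter) on the same core. Most of the gain from the methylamino compound to the benzyl(methyl)amino compound is therefore kept by a phenyl ring on the sulfonyl sulfur, although that ring has fewer heavy atoms than the benzyl(methyl)amino group, and compound 3 still stays lower beyond the scatter.

On these data alone, whether a cyclohexyl group, a pyridine ring or a phenyl ring carrying a methoxy group on the sulfonyl sulfur would match or pass these numbers remains open. What lies behind these steps is not addressed by any evidence given here.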